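Adding a second methyl to the aryl group of compound 3

The source may report more compounds than this note shows. Statements on the series, on what has been measured and on what is new or still open speak of the compounds shown alone.

Of the compounds shown here, three sharing one core have been tested in a functional assay on the whole organism (strain Wistar) for inhibition, with Rattus norvegicus as the target, read by paw edema, with a stated time of 4 h, at a dose of 10 mg/kg by the oral route; a lower number here means less inhibition, a higher number more inhibition at the dose given (going by the name of the read-out). Compound 1 `CCCCn1c(S)nnc1COc1ccc(-c2ccccc2)cc1` gives 81.8%, compound 2 `Fc1ccc(-n2c(S)nnc2COc2ccc(-c3ccccc3)cc2)cc1` gives 79.5%, and compound 3 `Cc1ccccc1-n1c(S)nnc1COc1ccc(-c2ccccc2)cc1` gives 59.1%. Compound 3 is the lowest of the three: the step of a number 22.7 percentage points lower from compound 1 to compound 3 (beyond the scatter) and the step of a number 20.4 percentage points lower from compound 2 to compound 3 (beyond the scatter) both lie beyond the scatter, while the step of a number 2.3 percentage points lower from compound 1 to compound 2 (within the scatter) does not.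

Compound 4 `Cc1ccc(-n2c(S)nnc2COc2ccc(-c3ccccc3)cc2)c(C)c1` has not been measured. It differs from compound 3 by methyl in place of hydrogen on an aromatic carbon. For the measured compounds named here, no measured step changes a substituent on that ring itself; the two steps that reach compound 3 swap the whole group on the aromatic nitrogen, and they show only that the 2-methylphenyl compound sits below the butyl and 4-fluorophenyl compounds. Whether a further methyl on the ring moves the number is therefore not shown by anything measured here. The expectation is a step of a number 3.9 percentage points higher from compound 3 to compound 4 (within the scatter), roughly within the scatter, with a small upward lean because compound 2 with its 4-fluorophenyl gives 79.5% and carries a group in the same ring position. Compound 4 is estimated at 63%, between 45% and 80%.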

Compound 4, a percentage reported as inhibition, in the whole organism at one dose (the size of the read-out at that dose, not a potency): 54.5%
Compound 4: middle estimate off by 8.5 percentage points, on the high side, within the range that was stated.
By their numbers in this assay, from the lowest: compounds 4 and 3 (each within the scatter of the next); then compounds 2 and 1 (each within the scatter of the next).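

For the compounds shown here, compound 4 gives the only measured step that alters the ring of the aryl group instead of swapping the whole group on the aromatic nitrogen, and in this assay going from 2-methylphenyl to 2,4-dimethylphenyl gives (a number 4.6 percentage points lower from compound 3 to compound 4 (within the scatter)), so this added methyl has no effect that can be told from the scatter. The 2,4-dimethylphenyl group also reads below the two groups that gave the highest numbers, with (a number 25 percentage points lower from compound 2 to compound 4 (beyond the scatter)) and (a number 27.3 percentage points lower from compound 1 to compound 4 (beyond the scatter)), so the gap first seen with compound 3 holds for a second methyl-bearing aryl group. Nothing in the data given explains these numbers.

Still open, on these data alone, is whether a 4-methylphenyl group or an unsubstituted phenyl on the aromatic nitrogen would read like compound 2 or like compound 3, which would help separate the contribution of each methyl from that of the aryl group as a whole. As far as these compounds go, it is also open whether a different group in place of the added methyl, such as a methoxy group, an amine or a carboxylic acid, would move the number beyond the scatter.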